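Hydrazone series: aryl swap on the imine carbon

A few compounds are considered here, and "the series" means these few. Any claim that something is new, unique, unknown or untested is made for them only; others in the source may bear on it.

Of the compounds shown here, three of one hydrazone series have been measured in a functional assay, read by spectrophotometry, with a stated time of 15 min, tested at 100 ug/mL; a lower number here means a weaker effect, a higher number a stronger effect of the compound at the concentration tested. Compound 1 `COC(=O)c1cc(-c2csc(N/N=C/c3ccc(Cl)cc3Cl)n2)ccc1OCc1ccccc1` gives 75%, the lowest of the three numbers. Among the compounds with values here, compound 3 `Clc1ccc(/C=N/Nc2nc(-c3ccccc3)cs2)c(Cl)c1` gives 87.4%, and compound 2 `Fc1ccc(-c2csc(N/N=C/c3cccs3)n2)cc1` gives 92.4%; both stand beyond the scatter above compound 1, while compound 2 and compound 3 lie within the scatter of each other and differ in more than one place, so no single step between them is computed.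

Compound 4 `COC(=O)c1cc(-c2csc(N/N=C/c3cccs3)n2)ccc1OCc1ccccc1` follows from compound 1 by the change (thiophen-2-yl in place of 2,4-dichlorophenyl on a carbon with a double bond to nitrogen). Within the data shown here, no measured pair isolates this change. A small rise is expected, because the thiophen-2-yl compound 2 gives 92.4% in this assay. The step of a number 5 percentage points higher from compound 1 to compound 4 (within the scatter) is an estimate only. Compound 4 is expected to give 80%, within 66% to 93%.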

Compound 4, a percentage reported as inhibition, at one concentration (the size of the read-out at that concentration, not a potency): 92.4%
Estimate against measurement, compound 4: 12.4 percentage points below, within the range that was stated.
By their numbers in this assay, from the lowest: compound 1; then compounds 3, 2 and 4 (each within the scatter of the next).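

In this assay, thiophen-2-yl in place of 2,4-dichlorophenyl on a carbon with a double bond to nitrogen gives a number 17.4 percentage points higher from compound 1 to compound 4 (beyond the scatter). Within the data shown here, this is the only step that changes one place, and it shows that the group at this position matters on the core of compound 1. No evidence is available to explain the step.

A plain phenyl at this carbon would separate the loss of the two chlorine atoms from the change of ring. As far as these compounds go, a carboxylic acid or a longer alkyl chain here remains open, as does whether the step holds on another core.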